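The source may hold more compounds than are shown below. What is called first, only, known or untested is meant among the compounds shown, and "the series" means these compounds.

Working notes on the series, with values from a functional assay (aorta) with Rattus norvegicus as the target (on this read-out lower numbers stand for an effect already at smaller amounts and higher numbers for an effect only at larger amounts of compound), and a shared core throughout.

- compound 1 `CC(C)NC1=NS(=O)(=O)c2cc(Cl)ccc2N1` gives 36.3 uM in this read-out
- compound 2 `CCNC1=NS(=O)(=O)c2cc(F)ccc2N1` gives > 300 uM as a limit of the assay and not a number
- compound 3 `CNC1=NS(=O)(=O)c2cc(Cl)ccc2N1` gives 142 uM in this read-out

Compound 4 `CCNC1=NS(=O)(=O)c2cc(Cl)ccc2N1` has not yet been measured.

Of the two values that are true numbers, compound 3 holds the higher at 142 uM and compound 1 is its nearest neighbour. The change to compound 4 is methyl in place of hydrogen on a saturated chain carbon bound to an amine nitrogen and it turns methylamino into ethylamino.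

Within the data shown here, one measured step bears on this change, namely a 3.9-fold higher number from compound 1 to compound 3 (0.59 log units; beyond the scatter) for methyl in place of isopropyl on an amine nitrogen. Ethyl is the middle member of the run from methyl to isopropyl, so a lower number than that of compound 3 is expected in this assay and the step should cover only part of the one measured. The expected step is a 2.0-fold lower number from compound 3 to compound 4 (0.31 log units; beyond the scatter) and it lies near the edge of the scatter. For compound 4 the estimated value is 70 uM with an expected range from 35 uM to 150 uM in this read-out.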

Compound 4, concentration for half-maximal effect: 39.9 uM
The estimate for compound 4 lay 1.8-fold (0.24 log units) above the measured number, within the range that was stated.
By their numbers in this assay, from the lowest: compounds 1 and 4 (each within the scatter of the next); then compound 3. At a limit, above all of these: compound 2.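

In this assay, the one added methyl that turns methylamino into ethylamino gives a 3.6-fold lower number from compound 3 to compound 4 (0.55 log units; beyond the scatter), whereas the earlier step between methyl and isopropyl could not show where along that run the change arises. Ethylamino and isopropylamino cannot be told apart, with a 1.1-fold higher number from compound 1 to compound 4 (0.04 log units; within the scatter), so among these three compounds the gain is complete at ethyl. Chloro in place of fluoro on the aromatic carbon gives an at least 7.5-fold lower number from compound 2 to compound 4 (0.87 log units; beyond the scatter), a step bounded on one side only, with compound 2 standing at a limit of the assay: the limit of > 300 uM in this assay, at which 1 of the 4 values shown sits.

Open, going by these compounds, is whether a longer chain such as propyl or butyl on the amine nitrogen holds this level or departs from it. Equally open, on these data alone, is how bromo or trifluoromethyl on the aromatic carbon would compare with chloro.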